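Changing the aromatic end of compound 2

The compounds below may be only part of what the source reports. "The series", "measured", "known", "first", "only" and "open" are said of these compounds alone.

Compound 2 `COCc1cccc(C[C@H](O)/C=C/[C@H]2CCCC(=O)N2CCCCCCC(=O)O)c1` is tested in a functional assay with prostaglandin E2 receptor EP4 subtype (Homo sapiens) as the target (on this read-out lower numbers stand for an effect already at smaller amounts and higher numbers for an effect only at larger amounts of compound), where compound 2 gives 44 nM. Compound 1 `COCc1cccc(C[C@H](O)/C=C/[C@H]2CCCC(=O)N2CCSCCCC(=O)O)c1` gives 44 nM, and the step between them, no change at the digits printed from compound 1 to compound 2 (within the scatter), shows the two standing level. Compound 3 `Cc1cc(C[C@H](O)/C=C/[C@H]2CCCC(=O)N2CCCCCCC(=O)O)ccc1O` differs in another way: 4-hydroxy-3-methylphenyl in place of 3-(methoxymethyl)phenyl on a saturated chain carbon, two bonds along the chain from a double-bonded chain carbon and an oxygen on a saturated carbon. For the measured compounds named here, the single measured step concerns the exchange of (3-carboxypropyl)sulfanyl for 4-carboxybutyl, not this aromatic group, so no measured step bears on the change. Without guidance, a modest weakening is expected, a 2.3-fold higher number from compound 2 to compound 3 (0.36 log units; beyond the scatter), so compound 3 is estimated at 100 nM, with a range from 20 nM to 500 nM.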

Compound 3, half-maximal effective concentration: 280 nM
The estimate for compound 3 lay 2.8-fold (0.45 log units) below the measured number; measured number inside the range.
By their numbers in this assay, from the lowest: compounds 1 and 2 (each within the scatter of the next); then compound 3.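

In this assay, the aromatic end matters in a way the chain exchange did not: 4-hydroxy-3-methylphenyl in place of 3-(methoxymethyl)phenyl gives a 6.4-fold higher number from compound 2 to compound 3 (0.80 log units; beyond the scatter), whereas the earlier step gave no change at the digits printed from compound 1 to compound 2 (within the scatter). So the group on this saturated chain carbon can shift the read-out even when the rest of the molecule stays the same. Nothing available explains this shift. 

The exchange removes the methoxymethyl group and adds both a hydroxyl and a methyl, so the compounds shown cannot separate their contributions. Going by these compounds, whether a plain 4-hydroxyphenyl or 3-methylphenyl group would stand nearer compound 2 or compound 3 remains open.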